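Methylpyridyl ether in place of chloropyridyl ether

The source may report more compounds than this note shows. Statements on the series, on what has been measured and on what is new or still open speak of the compounds shown alone.

Compound 1 `Cn1c(COc2cccc(C(=O)O)c2)nc2ccc(Oc3ccc(Cl)c(F)c3)nc21`: 2.2
Compound 2 `Cn1c(COc2cccc(C(=O)O)c2)nc2ccc(Oc3ccc(Cl)cn3)cc21`: 1.2
Compound 3 `Cn1c(COc2cccc(C(=O)O)c2)nc2ccc(Oc3cc(Cl)ccn3)cc21`: 1.2

Of the compounds shown here, three have been measured in a physicochemical assay for lipophilicity, read by LC-MS, in phosphate buffer, measured as octanol-water partition, with a stated time of 30 min, at pH 7.4, tested at 200 mM; a higher number here means a more lipophilic compound, a lower number a more polar compound. Compound 1 gives 2.2, compound 2 gives 1.2, and compound 3 gives 1.2. Compound 3 thus stands level with compound 2, the two together being the lowest of the three numbers, while compound 1 lies higher by a margin beyond the scatter. Compound 1 differs from compound 3 in more than one place, so only the two values themselves can be set against each other. Within the data shown here, the single one-point step among the measured compounds, no change at the digits printed from compound 2 to compound 3 (within the scatter), moved the chlorine on the pyridine ring without moving the number.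

Compound 4 `Cc1cccnc1Oc1ccc2nc(COc3cccc(C(=O)O)c3)n(C)c2c1` differs from compound 3 by 3-methylpyridin-2-yl in place of 4-chloropyridin-2-yl on an oxygen on an aromatic ring. Among the measured compounds shown here, no measured step exchanges a chlorine for a methyl group; the nearest step, no change at the digits printed from compound 2 to compound 3 (within the scatter), concerned the chlorine position only. The expected step from compound 3 to compound 4 is therefore small, a number 0.20 log units lower from compound 3 to compound 4 (within the scatter), at most a slight move downward and possibly none beyond the scatter. Compound 4 is estimated at 1 in this assay, with a range from 0.6 to 1.4.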

Compound 4, distribution coefficient: 0.9
Compound 4: middle estimate off by 0.10 log units, on the high side; the measured number falls inside the stated range.
By their numbers in this assay, from the lowest: compounds 4, 2 and 3 (each within the scatter of the next); then compound 1.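

In this assay, putting 3-methylpyridin-2-yl in place of 4-chloropyridin-2-yl on an oxygen on an aromatic ring gives a number 0.30 log units lower from compound 3 to compound 4 (within the scatter), and putting the same group in place of 5-chloropyridin-2-yl gives a number 0.30 log units lower from compound 2 to compound 4 (within the scatter). The earlier step had only moved the chlorine around the pyridine ring, whereas these two steps exchange the chlorine-bearing group for a methyl-bearing one, and compounds 2, 3 and 4 still all lie within the scatter of one another. Nothing available here bears on why these three readings stay together.

The compounds shown leave open whether an amine or a methoxy group on the same pyridine ring would also fall within the scatter of these three, and whether the methyl group would read the same on another carbon of that ring. On these data alone, compound 1 differs from each of them in more than one place, so it also remains open which of those differences goes with the value of 2.2 for compound 1.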